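Swapping a Naphthyl for a Chlorophenoxy Arm: Permeability Outlook

This account rests on a few compounds, and the source may have more. Where it says the series, first, only, none or still open, it means among the compounds named here.

Three compounds share a common core and were measured in an ADME assay for permeability, using PAMPA, with a stated time of 30 min, at pH 7.4; on this read-out lower numbers stand for lower permeability and higher numbers for higher permeability. Compound 1 `Clc1ccc(Oc2ccc3c(NCCCNCc4ccco4)ccnc3c2)cc1` gives 317 10^-6 cm/s in this assay. Compound 2 `c1coc(CNCCCNc2ccnc3cc(-c4cccc5ccccc45)ccc23)c1` gives 237 10^-6 cm/s. Compound 3 `COc1cccc(CNCCCNc2ccnc3cc(-c4cccc5ccccc45)ccc23)c1O` gives 237 10^-6 cm/s.

Two of these compounds differ in one place. From compound 2 to compound 1 the change is 4-chlorophenoxy in place of naphthalen-1-yl on an aromatic carbon, and this assay shows a 1.3-fold higher number from compound 2 to compound 1 (0.13 log units; within the scatter). From compound 2 to compound 3 the change is 2-hydroxy-3-methoxyphenyl in place of furan-2-yl on a saturated chain carbon bound to an amine nitrogen, and this assay shows no change at the digits printed from compound 2 to compound 3 (within the scatter). Compound 3 and compound 2 sit level with each other, and compound 1 lies within the usual scatter of both.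

Compound 4 `COc1cccc(CNCCCNc2ccnc3cc(Oc4ccc(Cl)cc4)ccc23)c1O` has not yet been measured. It differs from compound 3 by 4-chlorophenoxy in place of naphthalen-1-yl on an aromatic carbon, which is the same change as the one from compound 2 to compound 1, made on a core that differs from the core of compound 2 by the change described above. Because that earlier step read a 1.3-fold higher number from compound 2 to compound 1 (0.13 log units; within the scatter), the expectation is that the same change on compound 3 will again move the number little, and the step from compound 3 to compound 4 is estimated at a 1.3-fold higher number from compound 3 to compound 4 (0.10 log units; within the scatter). On that basis compound 4 is expected to give about 300 10^-6 cm/s in this assay, with a likely range from 180 10^-6 cm/s to 480 10^-6 cm/s.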

Compound 4, apparent permeability: 317 10^-6 cm/s
Compound 4: the middle estimate sits 1.1-fold (0.02 log units) below what was measured, and the stated range covers the measured number.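

Measured in this assay, placing 4-chlorophenoxy where naphthalen-1-yl stood gives a 1.3-fold higher number from compound 3 to compound 4 (0.13 log units; within the scatter), and placing 2-hydroxy-3-methoxyphenyl where furan-2-yl stood gives no change at the digits printed from compound 1 to compound 4 (within the scatter). The first of these changes reads the same on the two cores that carry it, so here it transfers from one core to the other without a visible difference: the same change on two cores in this assay, a 1.3-fold higher number (0.13 log units; within the scatter) from compound 2 to compound 1 and a 1.3-fold higher number (0.13 log units; within the scatter) from compound 3 to compound 4, 1.0-fold (0.00 log units) apart, within the scatter of two such steps. Within the data shown here, the second change also reads the same on both of its cores, but every step in this set lies within the usual scatter, so the agreement shows only that neither change stands out from the noise on these two cores, not that either one truly raises the number or that the match would hold on a third core: the same change on two cores in this assay, no change at the digits printed (within the scatter) from compound 2 to compound 3 and no change at the digits printed (within the scatter) from compound 1 to compound 4, 1.0-fold (0.00 log units) apart, within the scatter of two such steps.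

These four compounds form a single square of two changes, so they leave open how the read-out would respond to a group of a very different kind, such as a carboxylic acid or an amine, in place of 4-chlorophenoxy or 2-hydroxy-3-methoxyphenyl. They also leave open what a longer chain in place of the one linking the two nitrogens would do, and whether a change large enough to stand clear of the scatter would carry from core to core as closely as these small ones do.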